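The source may report more compounds than this note shows. Statements on the series, on what has been measured and on what is new or still open speak of the compounds shown alone.

Compound 1 `CN(C)C(=O)c1cc2cnc(Nc3ccc(N)cn3)nc2n1C1CCCC1`: 68%
Compound 2 `CN(C)C(=O)c1cc2cnc(Nc3ccc(NC(=O)C4(C(=O)Nc5ccc(Br)cc5)CC4)cc3)nc2n1C1CCCC1`: 87.8%

In a functional assay on OVCAR-5 cells (Homo sapiens) for inhibition, read by CCK-8 assay, with a stated time of 72 h, tested at 10 uM (on this read-out lower numbers stand for less inhibition of growth and higher numbers for more inhibition of growth at the one concentration tested), compound 2 gives 87.8%, the higher of the two numbers, and compound 1 lies beyond the scatter beneath it. Compound 3 `CN(C)C(=O)c1cc2cnc(Nc3ccc(NC(=O)C4(C(=O)Nc5ccccc5)CC4)cc3)nc2n1C1CCCC1` differs from compound 2 in one place: hydrogen in place of bromo on an aromatic carbon. This puts hydrogen in place of bromo on an aromatic carbon, turning 4-bromophenyl into phenyl. Among the compounds with values here, no measured pair shows this change, so a small fall within the scatter is expected, starting from compound 2 at 87.8%. The expected change is a number 5.8 percentage points lower from compound 2 to compound 3 (within the scatter). For compound 3, the estimate is 82%, with an expected range of 68% to 93%.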

Compound 3, percent growth inhibition at one concentration: 77.1%
Estimate against measurement, compound 3: 4.9 percentage points above, and the stated range covers the measured number.
By their numbers in this assay, from the lowest: compounds 1 and 3 (each within the scatter of the next); then compound 2.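

In this assay, the bromo on the aromatic carbon, para to a large group, proves to matter: replacing it with hydrogen gives a number 10.7 percentage points lower from compound 2 to compound 3 (beyond the scatter) and so 4-bromophenyl and phenyl are not interchangeable here, though the step is modest. Within the data shown here, this is the first comparison that isolates a single place. No available evidence explains the difference. The compounds shown leave open whether chloro, methoxy or a carboxylic acid on this same carbon would match the bromo. They also leave open how a bromo on another carbon of this ring would compare.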